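Moving the Bromine Atom: From Compound 1 to Compound 3

The compounds below may be only part of what the source reports. "The series", "measured", "known", "first", "only" and "open" are said of these compounds alone.

Compound 1, `O=C(COc1cccc2ccccc12)N/N=C/c1ccccc1Br`, was tested in an ADME assay on HEL cells (Homo sapiens) for cytotoxicity (a higher number here means that more compound is tolerated, a lower number that less compound is tolerated), and compound 1 gives 100 ug/mL, the higher of the two numbers recorded so far. Among the compounds with values here, the only other measured compound is compound 2, `C/C(=N\NC(=O)COc1cccc2ccccc12)c1ccc(Br)cc1`, and in this assay compound 2 gives 15.3 ug/mL, a difference to compound 1 that lies beyond the usual scatter. Within the data shown here, compound 2 differs from compound 1 in more than one place, so no single step between measured compounds can be read from these two numbers.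

Compound 3, `O=C(COc1cccc2ccccc12)N/N=C/c1cccc(Br)c1`, has not yet been measured. It differs from compound 1 in one place: 3-bromophenyl in place of 2-bromophenyl on a carbon with a double bond to nitrogen. Among the measured compounds shown here, no measured pair shows the effect of this change, so the expectation rests on compound 1 alone.

The step of a 1.4-fold lower number from compound 1 to compound 3 (0.15 log units; within the scatter) is expected to be small, most likely within the scatter, with a slight lean towards a lower number. For compound 3 in this assay the estimate is 70 ug/mL, within a range from 25 ug/mL to 150 ug/mL.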

Compound 3, half-maximal cytotoxic concentration: 48.6 ug/mL
Compound 3: middle estimate off by 1.4-fold (0.16 log units), on the high side, and the stated range covers the measured number.
By their numbers in this assay, from the lowest: compound 2; then compound 3; then compound 1.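

Within the data shown here, this is the first step between measured compounds that differ in one place: in this assay, putting 3-bromophenyl in place of 2-bromophenyl on a carbon with a double bond to nitrogen gives a 2.1-fold lower number from compound 1 to compound 3 (0.31 log units; beyond the scatter). Both groups hold the same atoms and the rest of the molecule stays the same, so the step comes from where the bromine sits on the ring, and this position in the compound is shown to respond to that move alone, though only to a modest degree. Nothing measured here bears on why the number moves in this direction, so the step stands as an observation without an explanation.

As far as these compounds go, whether the same move with a chlorine atom or a methoxy group in place of the bromine would give a step of similar size remains open, as does what a plain phenyl ring without any bromine would give. Among these compounds, compound 2 differs from both of the others in more than one place, so no single step linking it to them can be read.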